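The source may hold more compounds than are shown below. What is called first, only, known or untested is meant among the compounds shown, and "the series" means these compounds.

Measured compounds in a functional assay on MDA-MB-231 cells (Homo sapiens) for antiproliferative activity, read by CCK-8 assay, with a stated time of 72 h; on this read-out lower numbers stand for stronger inhibition and higher numbers for weaker inhibition:
Compound 1 `Cc1ccc(C(=O)Nc2cccc(-c3oc4cc(-c5ccc(F)cc5)ccc4c(=O)c3O)c2)cc1`: 4350 nM
Compound 2 `COc1ccccc1C(=O)Nc1cccc(-c2oc3cc(-c4ccc(F)cc4)ccc3c(=O)c2O)c1`: 5110 nM
Compound 3 `O=C(Nc1cccc(-c2oc3cc(-c4ccc(F)cc4)ccc3c(=O)c2O)c1)c1ccc(Cl)nc1`: 1760 nM

Compound 1 stands second highest of these three numbers; compound 2 sits within the scatter of it (a 1.2-fold higher number from compound 1 to compound 2 (0.07 log units; within the scatter)), while compound 3 lies beyond it (a 2.5-fold lower number from compound 1 to compound 3 (0.39 log units; beyond the scatter)). Compound 4 `N#Cc1ccc(C(=O)Nc2cccc(-c3oc4cc(-c5ccc(F)cc5)ccc4c(=O)c3O)c2)cc1` differs from compound 1 in one place: cyano in place of methyl on an aromatic carbon. Going by the values given here, both measured steps change the group on the carbonyl carbon, one giving no step beyond the scatter and one a modest lowering, so the change to compound 4, which alters only one group on that ring, is expected to give at most a modest lowering in this assay, a 1.5-fold lower number from compound 1 to compound 4 (0.16 log units; within the scatter). Compound 4 is therefore estimated at 3000 nM, between 1200 nM and 7500 nM.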

Compound 4, half-maximal inhibitory concentration: 11600 nM
Beside the measured number, compound 4's estimate is 3.9-fold (0.59 log units) below it; the measured number lies above the stated range.
By their numbers in this assay, from the lowest: compound 3; then compounds 1 and 2 (each within the scatter of the next); then compound 4.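

In this assay, going by these compounds alone, cyano in place of methyl on this ring raises the number (a step of a 2.7-fold higher number from compound 1 to compound 4 (0.43 log units; beyond the scatter)), so one small swap at this position can weaken inhibition, whereas the earlier steps on the carbonyl carbon were within the scatter or lowered the number. Compound 4 also stands above the other two compounds (steps of a 2.3-fold higher number from compound 2 to compound 4 (0.36 log units; beyond the scatter) and a 6.6-fold higher number from compound 3 to compound 4 (0.82 log units; beyond the scatter)). Nothing measured here explains this rise.

As far as these compounds go, with only methyl and cyano compared at this position, it remains open whether the rise is specific to cyano. An amine or a carboxylic acid at the same place could help show how other groups behave here.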